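Swapping a Benzyl Ester for a Methylthio Group

The source may hold more compounds than are shown below. What is called first, only, known or untested is meant among the compounds shown, and "the series" means these compounds.

Of the compounds shown here, three from this series have been tested in a functional assay on the whole organism (Tail, strain ICR) with Mus musculus as the target, in the tail flick test, with a stated time of 30 min, at a dose of 25 umol/kg by the oral route; a higher number here means a stronger effect of the compound at the dose given, a lower number a weaker effect. Compound 1, `O=C(CN(c1ncnc2c1ncn2C1CCCCO1)C1CC1)N[C@@H](CCC(=O)OCc1ccccc1)C(=O)OCc1ccccc1`, gives 32.6% in this assay, the highest of the three numbers, though the gaps to the other two compounds lie within the usual scatter. Compound 2, `O=C(O)CNC(=O)CN(c1nc(Cl)nc2[nH]cnc12)C1CC1`, gives 32.2%, and compound 3, `NC(=O)CC[C@H](NC(=O)CN(c1nc(Cl)nc2[nH]cnc12)C1CC1)C(=O)OCc1ccccc1`, gives 30.8%. Going by the values given here, with all three values so close, the numbers seen so far show no compound standing apart from the others.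

Compound 4, `CSCC[C@H](NC(=O)CN(c1ncnc2c1ncn2C1CCCCO1)C1CC1)C(=O)OCc1ccccc1`, has not yet been measured. It differs from compound 1 in one place: methylsulfanyl in place of benzyloxycarbonyl on a saturated chain carbon, three bonds along the chain from an amide-type nitrogen and a carbonyl carbon. Among the compounds with values here, no measured pair in this set isolates such a change, so its effect cannot be read from the data directly. Because compound 1 gives 32.6%, compound 2 gives 32.2% and compound 3 gives 30.8% despite their differing substituents, the expected step of a number 1.6 percentage points lower from compound 1 to compound 4 (within the scatter) is small, with no direction beyond the scatter. Compound 4 is therefore estimated to give 31% in this assay, within a range from 18% to 44%.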

Compound 4, a percentage reported as activity, at one dose (the size of the read-out at that dose, not a potency): 30%
Compound 4: the middle estimate sits 1 percentage points above what was measured; low and high end bracket the measured number.
By their numbers in this assay, from the lowest: compounds 4, 3, 2 and 1 (each within the scatter of the next).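

In this assay, the step on going from the 2-(benzyloxycarbonyl)ethyl group to the 2-(methylsulfanyl)ethyl group is a number 2.6 percentage points lower from compound 1 to compound 4 (within the scatter). This position therefore accepts a small sulfur-bearing group in place of a much larger ester with a six-membered aromatic ring, and the read-out stays within the scatter, so neither that ring nor the ester carbonyl is shown to matter here at this single dose. No other measurement bears on why the read-out holds.

On these data alone, whether an amine or a carboxylic acid on this saturated chain carbon would hold the read-out in the same way remains open. So does the effect of a longer chain carrying the methylsulfanyl group, which could show how far this position's tolerance extends.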